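Aryl ether variation on a pyrazole ester series

A few compounds are considered here, and "the series" means these few. Any claim that something is new, unique, unknown or untested is made for them only; others in the source may bear on it.

Measured in an assay for inhibition of Alpha amylase (Homo sapiens), with a stated time of 30 min; a higher number here means a weaker inhibitor, a lower number a stronger inhibitor:
Compound 1 `CCOC(=O)c1c(-c2ccccc2)nn(-c2ccccc2)c1Cn1c(S)nc2ccc(OC(F)F)cc21` gives 10 ug/mL.
Compound 2 `CCOC(=O)c1c(-c2ccccc2)nn(-c2ccccc2)c1COCc1c(-c2ccc(F)cc2)nc(N(C)S(C)(=O)=O)nc1C(C)C` gives 15 ug/mL.
Compound 3 `CCOC(=O)c1c(-c2ccccc2)nn(-c2ccccc2)c1COc1cc(OC)c(C=O)c(OC)c1` gives 40 ug/mL.

Compound 3 has the highest number of the three; its gap to compound 2 and its larger gap to compound 1 both lie beyond the usual scatter, so compound 3 is the weakest inhibitor here.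

Compound 4 `CCOC(=O)c1c(-c2ccccc2)nn(-c2ccccc2)c1COc1ccc(C=O)cc1OC` is not yet measured. It differs from compound 3 in one place: a group of 10 heavy atoms (8 carbon, 2 oxygen; one six-membered aromatic ring of carbon only) in place of a group of 12 heavy atoms (9 carbon, 3 oxygen; one six-membered aromatic ring of carbon only), on an oxygen on a saturated carbon. For the measured compounds named here, no step between measured compounds isolates a change of this kind, so the step of a 1.1-fold lower number from compound 3 to compound 4 (0.06 log units; within the scatter) is expected to be small, in no direction beyond the scatter.

Compound 4 is expected to give 35 ug/mL, within a range from 15 ug/mL to 90 ug/mL.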

Compound 4, half-maximal inhibitory concentration: 60 ug/mL
Compound 4: the middle estimate sits 1.7-fold (0.23 log units) below what was measured; the range from low to high includes it.
By their numbers in this assay, from the lowest: compounds 1 and 2 (each within the scatter of the next); then compounds 3 and 4 (each within the scatter of the next).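

The group on the oxygen on a saturated carbon goes from the group of 12 heavy atoms in compound 3 to 4-formyl-2-methoxyphenyl, and this assay gives a 1.5-fold higher number from compound 3 to compound 4 (0.18 log units; within the scatter) in response. For the compounds shown here, this is the first single-place step, and within the scatter the two groups cannot be told apart, so the methoxy group absent from compound 4 shows no measurable effect here. No measured data bear on why this is so.

Going by these compounds alone, whether the formyl group matters stays open, as no step here changes it alone. An amine or a carboxylic acid in its place is also untested in the compounds shown.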